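The source may hold more compounds than are shown below. What is called first, only, known or untested is meant among the compounds shown, and "the series" means these compounds.

Measured so far:
compound 1 `CNC(=O)c1cc(C(=O)NC2CC2)cn(CC2CCCOC2)c1=O` — 2 in a physicochemical assay for lipophilicity, at pH 7.4; a higher number here means a more lipophilic compound, a lower number a more polar compound
compound 2 `CNC(=O)c1cc(C(=O)NCCOC)cn(Cc2ccccc2)c1=O` — 2.7 in this assay

Compound 1 stands lowest of the two numbers; the nearest, compound 2, sits higher by a gap that lies beyond the scatter. For the measured compounds named here, no pair of measured compounds differs in one place only, so no single change has a measured size.

Compound 3 `CNC(=O)c1cc(C(=O)NC2CC2)cn(Cc2ccc(F)cc2)c1=O` is not yet measured. Relative to compound 1 the change is 4-fluorophenyl in place of oxan-3-yl on a saturated chain carbon bound to an aromatic nitrogen. Cut one bond further out, the same change reads (oxan-3-yl)methyl to 4-fluorobenzyl.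

For compound 3 an upward step in this assay is expected, beyond the scatter, since compound 2 with its aromatic six-membered ring on the same chain carbon gives 2.7 while compound 1 gives 2. The expected step of a number 1.00 log units higher from compound 1 to compound 3 (beyond the scatter) is upward. Compound 3 is estimated at 3, with a range from 2.5 to 3.5.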

Compound 3, distribution coefficient: 3.2
Estimate against measurement, compound 3: 0.20 log units below, within the range that was stated.
By their numbers in this assay, from the lowest: compound 1; then compound 2; then compound 3.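

In this assay, for the compounds shown here, the change from oxan-3-yl to 4-fluorophenyl on a saturated chain carbon bound to an aromatic nitrogen now has a measured size of a number 1.20 log units higher from compound 1 to compound 3 (beyond the scatter) and counts as large, the first single change that can be read. The step covers several differences at once, since the ring oxygen leaves, the ring becomes aromatic and a fluorine enters, and this one pair does not divide the step among them. Going by these compounds alone, nothing measured so far bears on why the step has this size.

Open, as far as these compounds go, is where a plain phenyl without the fluorine would fall at this position, and where a ring carrying an amine, such as piperidin-3-yl, would fall. Also open, from the compounds shown here alone, is whether the step keeps its size with another amide group on the shared core.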